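This account rests on a few compounds, and the source may have more. Where it says the series, first, only, none or still open, it means among the compounds named here.

In a physicochemical assay for permeability, using PAMPA (on this read-out lower numbers stand for lower permeability and higher numbers for higher permeability), compound 1 `Cc1cc(C)c(-c2nc(CN3CCC(C(=O)NCCCN4C[C@H](C)C[C@H](C)C4)CC3)c(C)o2)c(C)c1` stands as "not determined" (no result reported). Compound 2 `Cc1oc(-c2ccc(Cl)cc2)nc1CN1CCC(C(=O)NCCCN2C[C@H](C)C[C@H](C)C2)CC1` reads > 635 10^-6 cm/s, which is a limit of the assay and not a number. Among the measured compounds shown here, compound 3 `Cc1oc(-c2c(F)cccc2F)nc1CN1CCC(C(=O)NCCCN2C[C@H](C)C[C@H](C)C2)CC1`, at 82.4 10^-6 cm/s, carries the only actual number so far.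

Compound 4 `Cc1cccc(F)c1-c1nc(CN2CCC(C(=O)NCCCN3C[C@H](C)C[C@H](C)C3)CC2)c(C)o1` departs from compound 3 by methyl in place of fluoro on an aromatic carbon, ortho to a large group, so 2,6-difluorophenyl becomes 2-fluoro-6-methylphenyl.

For the measured compounds named here, one measured step bears on this: an at least 7.7-fold lower number from compound 2 to compound 3 (0.88 log units; beyond the scatter), with 2,6-difluorophenyl in place of 4-chlorophenyl. Its size is open-ended and it exchanges a different group, so it guides the direction only loosely. Compound 3, at 82.4 10^-6 cm/s, sits at the low end of that step, and a small upward move is expected in this assay when one fluoro gives way to methyl. The expected change is a 1.8-fold higher number from compound 3 to compound 4 (0.26 log units; within the scatter). For compound 4 the estimate is 150 10^-6 cm/s, with an expected range from 60 10^-6 cm/s to 400 10^-6 cm/s.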

Compound 4, apparent permeability: 234 10^-6 cm/s
Compound 4: the middle estimate sits 1.6-fold (0.19 log units) below what was measured, and the stated range covers the measured number.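

In this assay, among the compounds shown here, methyl in place of fluoro on an aromatic carbon, ortho to a large group, gives a 2.8-fold higher number from compound 3 to compound 4 (0.45 log units; beyond the scatter) and so supplies the first step with a real number at both ends. Against 4-chlorophenyl, the change to 2-fluoro-6-methylphenyl gives an at least 2.7-fold lower number from compound 2 to compound 4 (0.43 log units; beyond the scatter) and takes back only part of the drop seen with 2,6-difluorophenyl, by an amount that stays open. Compound 2 stands at a limit of the assay and not at a number: the limit of > 635 10^-6 cm/s in this assay, at which 1 of the 4 values shown sits.

From the compounds shown here alone, whether a chloro, a methoxy or an amine on this same carbon would move the read-out further remains open. Also open, going by these compounds, is whether methyl in place of the remaining fluoro would extend the rise.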